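Tert-butoxycarbonyl Capping of Two Spiro Amines and Cytotoxicity

The compounds below may be only part of what the source reports. "The series", "measured", "known", "first", "only" and "open" are said of these compounds alone.

Compound 1 `Cc1cc(C)cc(S(=O)(=O)c2c(C(=O)NC3CC4(CCNC4)C3)[nH]c3ccc(Cl)cc23)c1` and compound 3 `Cc1cc(C)cc(S(=O)(=O)c2c(C(=O)NC3CC4(CNC4)C3)[nH]c3ccc(Cl)cc23)c1` share a core and differ only in the amine-bearing ring: a group of 7 heavy atoms (6 carbon, 1 nitrogen; one four-membered non-aromatic ring of carbon only, one four-membered non-aromatic ring with 1 hetero atom) in place of a group of 8 heavy atoms (7 carbon, 1 nitrogen; one four-membered non-aromatic ring of carbon only, one five-membered non-aromatic ring with 1 hetero atom), on an amide-type nitrogen. In a toxicity assay on MT4 cells (Homo sapiens) for cytotoxicity, read by MTT assay, with a stated time of 7 days (on this read-out higher numbers stand for lower toxicity in this test and lower numbers for higher toxicity in this test), compound 1 gives 25300 nM, and compound 3 gives 28600 nM, so a 1.1-fold higher number from compound 1 to compound 3 (0.05 log units; within the scatter). Compound 2 `Cc1cc(C)cc(S(=O)(=O)c2c(C(=O)NC3CC4(CCN(C(=O)OC(C)(C)C)C4)C3)[nH]c3ccc(Cl)cc23)c1` carries tert-butoxycarbonyl in place of hydrogen on an amine nitrogen in a ring on the core of compound 1, and in this assay compound 2 gives 171000 nM; a 6.8-fold higher number from compound 1 to compound 2 (0.83 log units; beyond the scatter). Compound 4 `Cc1cc(C)cc(S(=O)(=O)c2c(C(=O)NC3CC4(C3)CN(C(=O)OC(C)(C)C)C4)[nH]c3ccc(Cl)cc23)c1` carries the same kind of change on compound 3, (tert-butoxycarbonyl in place of hydrogen on an amine nitrogen in a ring), the place being a four-membered rather than a five-membered ring with 1 nitrogen. Since the two cores read alike, a step like the earlier one is expected: a 6.3-fold higher number from compound 3 to compound 4 (0.80 log units; beyond the scatter). In this assay compound 4 is therefore estimated at 180000 nM, within 70000 nM to 400000 nM.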

Compound 4, half-maximal cytotoxic concentration: > 224000 nM
Compound 4: no number, only a limit (the forecaster's own chance of this, stated with the estimate: 20%); middle value at least 1.2-fold (0.09 log units) from the limit.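

On both cores, tert-butoxycarbonyl in place of hydrogen on the ring amine nitrogen gives a higher number in this assay, which stands for lower toxicity in this test, with an at least 7.8-fold higher number from compound 3 to compound 4 (0.89 log units; beyond the scatter). Compound 4 gives > 224000 nM, which is a limit of the assay and not a number. The direction of the change therefore carries from the five-membered to the four-membered ring with 1 nitrogen, but the data do not show whether its size is the same on the two cores: the same change on two cores in this assay, a 6.8-fold higher number (0.83 log units; beyond the scatter) from compound 1 to compound 2 and an at least 7.8-fold higher number (0.89 log units; beyond the scatter) from compound 3 to compound 4; the limit leaves it open whether they differ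

The compounds shown leave open whether an acetyl group, a methyl group or a longer chain on the same amine nitrogen would give a step of this kind.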